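The source may hold more compounds than are shown below. What is called first, only, known or untested is meant among the compounds shown, and "the series" means these compounds.

In a functional assay on A2780 cells (Homo sapiens) for antiproliferative activity, read by CellTiter-Glo, with a stated time of 72 h (on this read-out lower numbers stand for stronger inhibition and higher numbers for weaker inhibition), compound 1 `C[C@H](NC(=O)c1cccc(F)c1)c1ccc(NC(=O)N2CC(c3cccnc3)C2)cc1` gives 2.3 nM and compound 2 `C[C@H](NC(=O)c1cccc(F)c1)c1ccc(NC(=O)N2CC(c3ccc(N)nc3)C2)cc1` gives 7.6 nM while compound 3 `C[C@H](NC(=O)c1cccc(F)c1)c1ccc(NC(=O)N2CC(c3cncc(N)c3)C2)cc1` gives 240 nM as the highest number of the three, with both gaps to it beyond the scatter. The next entry is compound 4 `CCC(=O)N[C@@H](C)c1ccc(NC(=O)N2CC(c3cncc(N)c3)C2)cc1` (ethyl in place of 3-fluorophenyl on a carbonyl carbon), and the counted change from compound 3 reads ethyl in place of 3-fluorophenyl on a carbonyl carbon with nothing else altered.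

The measured steps do not touch this carbonyl substituent: a 3.3-fold higher number from compound 1 to compound 2 (0.52 log units; beyond the scatter) is modest and a 100-fold higher number from compound 1 to compound 3 (2.02 log units; beyond the scatter) is large, both for amino in place of hydrogen on an aromatic carbon, and a 32-fold higher number from compound 2 to compound 3 (1.50 log units; beyond the scatter) is large for 5-aminopyridin-3-yl in place of 6-aminopyridin-3-yl. They bear on the new change only indirectly, showing that one change in this series can move the number by a modest or a large step. Within the data shown here, no measured compound carries ethyl at this carbonyl carbon. A step to a higher number in this assay is still expected, modest to large, as the aromatic ring leaves, though a step within the scatter cannot be ruled out. The expected step is a 3.8-fold higher number from compound 3 to compound 4 (0.57 log units; beyond the scatter) as an estimate with wide uncertainty. For compound 4 the estimated value is 900 nM within an expected range from 200 nM to 4000 nM in this read-out.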

Compound 4, half-maximal inhibitory concentration: 770 nM
For compound 4 the middle estimate is 1.2-fold (0.07 log units) above the measured one, within the range that was stated.
By their numbers in this assay, from the lowest: compound 1; then compound 2; then compound 3; then compound 4.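

Working notes on the carbonyl substituent, read in this assay: with the 5-aminopyridin-3-yl group held fixed, replacing 3-fluorophenyl by ethyl gives a 3.2-fold higher number from compound 3 to compound 4 (0.51 log units; beyond the scatter). Among these compounds, this is the first measured change at this carbonyl carbon, and it shows that the aromatic ring can leave, with 7 heavy atoms replaced by 2, at a modest cost, whereas moving the amino group gave a large step, a 32-fold higher number from compound 2 to compound 3 (1.50 log units; beyond the scatter). No evidence accompanies the new step to account for its size.

Among the compounds shown here, it remains open whether ethyl in place of 3-fluorophenyl would give a step of similar size on the background of compound 1 or compound 2, as the only reading of this change starts from the weaker compound 3. Also open, as far as these compounds go, is how a plain phenyl, a cyclopropyl, a longer chain such as butyl or a chain ending in an amine would compare at this carbonyl carbon; the plain phenyl in particular would separate the part played by the ring from that of the fluorine.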